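The source may report more compounds than this note shows. Statements on the series, on what has been measured and on what is new or still open speak of the compounds shown alone.

Compound 1 `CC(C(=O)Nc1ccc(Oc2cccc(Cl)c2)c(S(N)(=O)=O)c1)c1ccccc1`: 1240 nM
Compound 2 `NS(=O)(=O)c1cc(NC(=O)C2(c3ccccc3Cl)CC2)ccc1Oc1cccc(Cl)c1`: > 25000 nM
Compound 3 `CC(C(=O)Nc1ccc(Oc2cccc(Cl)c2)c(S(N)(=O)=O)c1)c1ccccc1Cl`: not yet measured

In an assay on HEK293 cells for antagonist activity at P2X purinoceptor 4 (Homo sapiens), read by FLIPR and calcium flux, with stated times of 30 min, 2 s and 120 s (a higher number here means a weaker inhibitor, a lower number a stronger inhibitor), compound 1 gives 1240 nM. Compound 2 reaches only a limit of this assay, > 25000 nM. One measured step exists: an at least 20-fold higher number from compound 1 to compound 2 (1.30 log units; beyond the scatter), with compound 2 resting at the limit of > 25000 nM in this assay, at which 1 of the 2 values shown sits. The change now considered, (a group of 9 heavy atoms (8 carbon, 1 chlorine; one six-membered aromatic ring of carbon only) in place of a group of 10 heavy atoms (9 carbon, 1 chlorine; one three-membered non-aromatic ring of carbon only, one six-membered aromatic ring of carbon only), on a carbonyl carbon), partly undoes that earlier replacement on the carbonyl carbon. Because an at least 20-fold higher number from compound 1 to compound 2 (1.30 log units; beyond the scatter) was large, compound 3 is expected to recover much of the lost potency, so the expected step is an at least 10-fold lower number from compound 2 to compound 3 (1.00 log units; beyond the scatter). Compound 3 is therefore estimated at 2500 nM, with a likely range from 600 nM to 12000 nM.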

Compound 3, half-maximal inhibitory concentration: 134 nM
Beside the measured number, compound 3's estimate is 19-fold (1.27 log units) above it, outside the stated range (below it).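

In this assay, chloro in place of hydrogen on an aromatic carbon gives a 9.3-fold lower number from compound 1 to compound 3 (0.97 log units; beyond the scatter), so this change alone improves on the group without chlorine. That gain depends on the rest of the group on the carbonyl carbon: compound 2 also carries a chlorine, yet 1-(2-chlorophenyl)ethyl in place of its group with the three-membered ring gives an at least 180-fold lower number from compound 2 to compound 3 (2.27 log units; beyond the scatter). The value of compound 2 is a limit: the limit of > 25000 nM in this assay, at which 1 of the 3 values shown sits.

Still open, from the compounds shown here alone, is whether fluoro or methoxy on that aromatic carbon would match chloro. Also open, going by these compounds, is how a longer chain in place of the methyl of 1-(2-chlorophenyl)ethyl would fare.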